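The source may report more compounds than this note shows. Statements on the series, on what has been measured and on what is new or still open speak of the compounds shown alone.

Measured compounds:
Compound 1 `CC1=C(C(=O)CC(C)C)C(c2cccs2)NC(=O)N1`: 18%
Compound 2 `CCC(CC)OC(=O)C1=C(C)NC(=O)NC1c1cccs1`: 1%

In an assay on membranes from HeLa cells for displacement of a labelled ligand from adenosine receptor A3 (Homo sapiens), read by scintillation counting, with a stated time of 180 min, tested at 1 uM (on this read-out lower numbers stand for less inhibition and higher numbers for more inhibition at the one concentration tested (going by the name of the read-out)), compound 2 gives 1%, the lower of the two numbers; compound 1 gives 18%. Among the measured compounds shown here, the single step measured, a number 17 percentage points lower from compound 1 to compound 2 (beyond the scatter), is the only one that bears here, and it concerns a different change.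

Compound 3 `CC1=C(C(=O)OC2CCC2)C(c2cccs2)NC(=O)N1` differs from compound 2 by cyclobutyl in place of pentan-3-yl on an oxygen next to a carbonyl group. For the measured compounds named here, no measured pair compares two groups on this oxygen, so compound 3 is expected to stay near compound 2, with a step of a number 5 percentage points higher from compound 2 to compound 3 (within the scatter) or none beyond the scatter. The estimate for compound 3 is 6%, range -5% to 20%.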

Compound 3, a percentage reported as inhibition, at one concentration (the size of the read-out at that concentration, not a potency): 2%
Compound 3: middle estimate off by 4 percentage points, on the high side; the measured number falls inside the stated range.
By their numbers in this assay, from the lowest: compounds 2 and 3 (each within the scatter of the next); then compound 1.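

On the oxygen next to a carbonyl group, cyclobutyl in place of pentan-3-yl gives a number 1 percentage points higher from compound 2 to compound 3 (within the scatter) in this assay, so these two groups cannot be told apart on this read-out. With cyclobutyloxy in place of isobutyl on the carbonyl carbon, the result is a number 16 percentage points lower from compound 1 to compound 3 (beyond the scatter), which makes two oxy groups on this carbon that stand apart from the isobutyl of compound 1. No evidence on the cause of either step is available.

Open, as far as these compounds go, is whether an amine on the carbonyl carbon would read like the oxy groups or like isobutyl. Also open, from the compounds shown here alone, is whether a longer chain on the oxygen would move the number at all.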